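A few compounds are considered here, and "the series" means these few. Any claim that something is new, unique, unknown or untested is made for them only; others in the source may bear on it.

Measured so far in a physicochemical assay for lipophilicity, using the shake flask method, at pH 7.4; a lower number here means a more polar compound, a higher number a more lipophilic compound:
compound 1 `CN(C)[C@H]1CC[C@H](Nc2ncnc3[nH]cc([C@H]4CC[C@H](C(N)=O)CC4)c23)CC1`: 0
compound 2 `CN(C)[C@H]1CC[C@H](Nc2ncnc3[nH]ccc23)CC1`: -0.6

Of these two numbers, compound 2 has the lower, at -0.6. The next structure, compound 3 `CN(C)[C@H]1CC[C@H](Nc2ncnc3[nH]cc([C@H]4CC[C@@H](C(N)=O)CC4)c23)CC1`, is reached from compound 2 by 4-carbamoylcyclohexyl in place of hydrogen on an aromatic carbon, two ring bonds from the ring nitrogen. Among the measured compounds shown here, one measured step bears on this change: a number 0.60 log units lower from compound 1 to compound 2 (beyond the scatter), where hydrogen replaces 4-carbamoylcyclohexyl, the reverse of the present exchange. The expectation therefore rests on a single pair. A step of similar modest size is expected in this assay, upward and beyond the scatter. The estimated step is a number 0.60 log units higher from compound 2 to compound 3 (beyond the scatter). For compound 3 the estimate is 0, with an expected range from -0.4 to 0.4.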

Compound 3, distribution coefficient: 0
Beside the measured number, compound 3's estimate shows no gap at the digits printed; the range from low to high includes it.
By their numbers in this assay, from the lowest: compound 2; then compounds 1 and 3 (each within the scatter of the next).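

In this assay, adding 4-carbamoylcyclohexyl on this aromatic carbon gives a number 0.60 log units higher from compound 2 to compound 3 (beyond the scatter), so the rise now holds for a second drawn configuration of the group and not for one alone. The two configurations do not separate in this measurement, with no change at the digits printed from compound 1 to compound 3 (within the scatter). This comparison isolates configuration, as the rest of the structure is shared: the fact that compounds 1 and 3 differ only in the configuration as drawn

How much of the step belongs to the cyclohexyl ring and how much to the carbamoyl group remains open, as both enter together in every comparison shown. Whether configuration stays equally silent with a carboxylic acid or an amine in place of the carbamoyl group on that ring, or whether an open propyl chain in place of the ring gives a similar step, is also unresolved.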